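Phenyl Exchanged for Pyrrole: What to Expect of Compound 3

The source may hold more compounds than are shown below. What is called first, only, known or untested is meant among the compounds shown, and "the series" means these compounds.

Measured so far:
compound 1 `CCOC(=O)C1=C(Nc2ccccc2)S/C(=C\c2ccccc2)C1=O` gives 42.9%
compound 2 `CCOC(=O)C1=C(Nc2ccccc2)S/C(=C\c2ccccc2C(F)(F)F)C1=O` gives 19.7%

Both numbers come from a functional assay on K562 cells (Homo sapiens) for inhibition, read by MTT assay, with a stated time of 72 h, tested at 10 uM; a lower number here means less inhibition, a higher number more inhibition at the concentration tested (going by the name of the read-out). Among the compounds with values here, of the two, compound 1 stands highest; its only neighbour is compound 2, reached by the single measured step of a number 23.2 percentage points lower from compound 1 to compound 2 (beyond the scatter), which puts trifluoromethyl onto the phenyl while leaving the rest of the shared core untouched.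

Compound 3 `CCOC(=O)C1=C(Nc2ccccc2)S/C(=C\c2cc[nH]c2)C1=O` has not yet been measured. It differs from compound 1 by 1H-pyrrol-3-yl in place of phenyl on a double-bonded chain carbon bound to a double-bonded ring carbon. Within the data shown here, no measured step bears directly on this: the one known step changes a substituent on the phenyl, whereas here the phenyl itself is exchanged for a smaller ring that carries a hydrogen-bond donor. The known step does show that this part of the molecule can move the read-out by a modest amount, so a shift of similar size in either direction is possible, but nothing here tells the direction.

For compound 3 the estimate is therefore close to compound 1, with a wide range: 38% (from 12% to 64%), an expected step of a number 4.9 percentage points lower from compound 1 to compound 3 (within the scatter).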

Compound 3, a percentage reported as inhibition, at one concentration (the size of the read-out at that concentration, not a potency): 18.9%
The estimate for compound 3 lay 19.1 percentage points above the measured number, within the range that was stated.
By their numbers in this assay, from the lowest: compounds 3 and 2 (each within the scatter of the next); then compound 1.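

In this assay, the step of a number 24 percentage points lower from compound 1 to compound 3 (beyond the scatter) shows that the read-out responds to exchanging the whole ring on this double-bonded chain carbon, and not only to adding a group to the phenyl. Alongside it stands the step of a number 23.2 percentage points lower from compound 1 to compound 2 (beyond the scatter), so both changes shown here, putting trifluoromethyl on the phenyl and replacing the phenyl with 1H-pyrrol-3-yl, give a lower number than compound 1 does. Because the change from phenyl to 1H-pyrrol-3-yl alters ring size, adds a ring nitrogen and adds a hydrogen-bond donor all at once, these compounds cannot show which of those differences matters, and no outside measurement is available to explain the drop.

From the compounds shown here alone, it remains open whether a pyridine or furan ring at this place, or a phenyl carrying an amine or a carboxylic acid, would stay near compound 1 or fall further. The compounds shown also leave open how the ethyl ester on the shared core contributes, since it is the same in all of them.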